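Swapping the methoxy on compound 1's cyclohexyl ring for a triazole

The source may hold more compounds than are shown below. What is called first, only, known or untested is meant among the compounds shown, and "the series" means these compounds.

Compound 1 `CO[C@H]1CC[C@@H](Nc2cc(NCc3cnccc3C(F)(F)F)ncc2C#N)CC1` gives 58 nM in an assay on isolated protein for inhibition of protein kinase C theta type (Homo sapiens), read by TR-FRET, with a stated time of 2 h; a lower number here means a stronger inhibitor, a higher number a weaker inhibitor. It has the lowest number of the three measured compounds: compound 2 `CO[C@H]1CC[C@H](CNc2cc(NCc3cnccc3C(F)(F)F)ncc2C#N)CC1` gives 330 nM, a change of a 5.7-fold higher number from compound 1 to compound 2 (0.76 log units; beyond the scatter), and compound 3 `N#Cc1cnc(NCc2cnccc2C(F)(F)F)cc1NCC1CCOCC1` gives 400 nM, a change of a 6.9-fold higher number from compound 1 to compound 3 (0.84 log units; beyond the scatter). Both of those steps alter the link between the core and the saturated ring. Compound 4 `N#Cc1cnc(NCc2cnccc2C(F)(F)F)cc1N[C@H]1CC[C@@H](n2cncn2)CC1` instead keeps that link and changes only the group on the ring: 1H-1,2,4-triazol-1-yl in place of methoxy on a saturated ring carbon. Among the compounds with values here, no measured step touches this position, so the effect of the change cannot be read from the steps at hand. Compound 4 is therefore expected to remain near compound 1, with an estimated 1.4-fold higher number from compound 1 to compound 4 (0.14 log units; within the scatter), giving an expected value of 80 nM, in a range from 25 nM to 300 nM.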

Compound 4, half-maximal inhibitory concentration: 100 nM
Estimate against measurement, compound 4: 1.3-fold (0.10 log units) below; measured number inside the range.
By their numbers in this assay, from the lowest: compounds 1 and 4 (each within the scatter of the next); then compounds 2 and 3 (each within the scatter of the next).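

The earlier compounds shown here changed only the link between the core and the saturated ring, whereas this step changes the group on that ring while the link stays the same. In this assay, 1H-1,2,4-triazol-1-yl in place of methoxy gives a 1.7-fold higher number from compound 1 to compound 4 (0.24 log units; within the scatter), so this ring carbon can carry a five-membered aromatic ring with no change beyond the scatter. No measurement here explains this result.

On these data alone, whether the same holds for an amine or a carboxylic acid on this ring carbon stays open.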